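Triazole series: cyclopentyl for isopropyl on the core

This account rests on a few compounds, and the source may have more. Where it says the series, first, only, none or still open, it means among the compounds named here.

Measured compounds:
- compound 1 `COC(=O)c1nc(C)n(-c2cccc(Br)c2)n1`; in a functional assay on Jurkat cells (Homo sapiens) for inhibition, read by MTT assay, with a stated time of 72 h (a lower number here means a stronger inhibitor of growth, a higher number a weaker inhibitor of growth), compound 1 gives > 100000 nM, a limit of the assay.
- compound 2 `COC(=O)c1nc(C)n(-c2cccc(C(F)(F)F)c2)n1`; in this assay compound 2 gives 10600 nM.
- compound 3 `COC(=O)c1nc(C(C)C)n(-c2ccc(F)cc2)n1`; in this assay compound 3 gives > 100000 nM, a limit of the assay.

Compound 3 stands at the limit, and the limit of > 100000 nM in this assay, at which 2 of the 3 values shown sit, shows that it shares this position with most of the series. Compound 4 `COC(=O)c1nc(C2CCCC2)n(-c2ccc(F)cc2)n1` differs from compound 3 in one place: cyclopentyl in place of isopropyl on an aromatic carbon.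

For the measured compounds named here, the only measured step, an at least 9.4-fold lower number from compound 1 to compound 2 (0.97 log units; beyond the scatter), concerns the group on the phenyl ring and not the aromatic carbon between two ring nitrogen atoms, so it gives no direct guide to the change from isopropyl to cyclopentyl. Going by the values given here, no measured pair bears on that change, and nothing in the numbers points to a direction. The expectation is therefore a step of no size beyond the scatter in this assay, that is a number no higher from compound 3 to compound 4 (the limit leaves the size open), with a high chance that only a limit is reported again. Compound 4 is expected at 100000 nM, within 30000 nM to 300000 nM.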

Compound 4, concentration for 50% growth inhibition: 9550 nM
Compound 4: the middle estimate sits 10-fold (1.02 log units) above what was measured; measured number outside the range, below it.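

In this assay the change from isopropyl to cyclopentyl gives an at least 10-fold lower number from compound 3 to compound 4 (1.01 log units; beyond the scatter), so the group on the aromatic carbon between two ring nitrogen atoms can, with the rest of the structure unchanged, bring a compound off the limit. From the compounds shown here alone, compound 3 gives > 100000 nM, which is a limit, so the true size of this step remains unknown. Until now the only readable step concerned the group on the phenyl ring, and this second readable step shows that the core position matters too, though limit values remain frequent in the series: the limit of > 100000 nM in this assay, at which 2 of the 4 values shown sit.

The compounds shown do not separate the effect of the cyclopentyl ring from that of its larger carbon count, and a straight pentyl chain at this position would tell the two apart. Also open, going by these compounds, is whether an amine on the cyclopentyl ring would keep the readable value.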